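The source may hold more compounds than are shown below. What is called first, only, known or untested is meant among the compounds shown, and "the series" means these compounds.

Read-outs in an assay on isolated protein for displacement of a labelled ligand from metabotropic glutamate receptor 5 (Homo sapiens), with a stated time of 60 min, tested at 1 uM; on this read-out lower numbers stand for less inhibition and higher numbers for more inhibition at the one concentration tested (going by the name of the read-out):

compound 1 `CC1CCN(c2c(S(=O)(=O)c3cccc(F)c3)cnc3ccc(F)cc23)CC1`: 76%
compound 2 `CC1CCN(c2c(S(=O)(=O)c3ccc(F)c(Cl)c3)cnc3ccc(F)cc23)CC1`: 95%

Compound 2 stands highest of the two numbers, with compound 1 nearest. Among the compounds with values here, the single measured step, a number 19 percentage points higher from compound 1 to compound 2 (beyond the scatter), alters the same aryl ring on the sulfonyl sulfur but by a different exchange. Compound 3 `COc1ccc(S(=O)(=O)c2cnc3ccc(F)cc3c2N2CCC(C)CC2)cc1Cl` differs from compound 2 by methoxy in place of fluoro on an aromatic carbon. Within the data shown here, no measured step exchanges fluoro for methoxy, so there is no direct guide; compound 2 already gives 95% in this assay, leaving little room upward. For compound 3 the expected step is a number 7 percentage points lower from compound 2 to compound 3 (within the scatter), nothing beyond the scatter. Compound 3 is estimated at 88%, within a range from 70% to 99%.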

Compound 3, a percentage reported as inhibition, at one concentration (the size of the read-out at that concentration, not a potency): 82%
Compound 3: middle estimate off by 6 percentage points, on the high side; low and high end bracket the measured number.
By their numbers in this assay, from the lowest: compounds 1 and 3 (each within the scatter of the next); then compound 2.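

In this assay, the carbon ortho to a chloro group and para to a large group is sensitive to its substituent: methoxy in place of fluoro gives a number 13 percentage points lower from compound 2 to compound 3 (beyond the scatter). 3-Chloro-4-methoxyphenyl in place of 3-fluorophenyl gives a number 6 percentage points higher from compound 1 to compound 3 (within the scatter), so keeping the chloro group does not by itself keep the level of compound 2. No available evidence accounts for this step.

Open, on these data alone, is how an amine or a hydroxyl group at this carbon would read, and whether a longer chain such as ethoxy would read differently from methoxy.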